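Anchoring compound 3 on a single measured neighbour

This account rests on a few compounds, and the source may have more. Where it says the series, first, only, none or still open, it means among the compounds named here.

compound 1 `CCc1nc2c(C)cc(-c3ccc(CN4CCN(C)CC4)cc3)cn2c1NC(=O)OCc1cc(Cl)cc(Cl)c1` gives "nd" (no result reported)
compound 2 `CCc1nc2c(C)cc(-c3ccc(CN4CCC(C)CC4)cc3)cn2c1NC(=O)OCc1cc(Cl)cc(Cl)c1` gives 5830 nM

Among the compounds with values here, in a functional assay on MDA-MB-231 cells (Homo sapiens) for inhibition, read by MTT assay, with a stated time of 72 h (a higher number here means a weaker inhibitor, a lower number a stronger inhibitor), compound 2, at 5830 nM, holds the only number, so it cannot be ranked against anything, and compound 1 offers no comparison. The next compound, compound 3 `CCc1nc2c(C)cc(-c3ccc(CNCCO)cc3)cn2c1NC(=O)OCc1cc(Cl)cc(Cl)c1`, keeps the shared core and differs in one place. The change (2-hydroxyethyl)amino in place of 4-methylpiperidin-1-yl on a saturated chain carbon bound to an aromatic carbon puts (2-hydroxyethyl)amino in place of 4-methylpiperidin-1-yl on a saturated chain carbon bound to an aromatic carbon. Within the data shown here, no pair of measured compounds shows what such a swap does, so the expectation is loose. The estimated step of a 1.4-fold higher number from compound 2 to compound 3 (0.14 log units; within the scatter) is small and points, if anywhere, toward weaker inhibition. Compound 3 is expected near 8000 nM in this assay, with an estimated range from 2500 nM to 25000 nM as its likely span.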

Compound 3, half-maximal inhibitory concentration: > 20000 nM
Compound 3: only a limit was reported; the forecaster's own chance of this, stated with the estimate: 15%; middle value at least 2.5-fold (0.39 log units) away from the limit.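

In this assay compound 3 gives > 20000 nM, which is a limit and not a number. Even so, the step can be read in one direction: putting (2-hydroxyethyl)amino in place of 4-methylpiperidin-1-yl on a saturated chain carbon bound to an aromatic carbon gives an at least 3.4-fold higher number from compound 2 to compound 3 (0.53 log units; beyond the scatter), so the group at this place does affect the read-out. The full size of the step cannot be told, and only its lower edge is fixed: the limit of > 20000 nM in this assay, at which 1 of the 3 values shown sits.

The swap removes the ring and brings in the hydroxyl in one change, and the compounds shown do not separate the two. Compound 1 offers no comparison, and an open-chain amine without the hydroxyl, such as diethylamino, or a morpholine ring carrying the oxygen within it, would tell these two parts apart.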